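This account rests on a few compounds, and the source may have more. Where it says the series, first, only, none or still open, it means among the compounds named here.

Three dicinnamoyl ketones carrying a coumarin-linked triazole through an aryl ether were tested in a functional assay on HCT-116 cells (Homo sapiens) for inhibition, read by sulforhodamine B assay, with a stated time of 48 h, tested at 50 uM; on this read-out higher numbers stand for more inhibition of growth at the one concentration tested and lower numbers for less inhibition of growth. Compound 1, `COc1ccc(/C=C/C(=O)/C=C/c2ccc(OCc3cn(CCCCOc4cc(=O)oc5ccccc45)nn3)c(OC)c2)cc1OC`, gives 55%; compound 2, `COc1cc(/C=C/C(=O)/C=C/c2cc(OC)c(OC)c(OC)c2)ccc1OCc1cn(CCCCOc2cc(=O)oc3ccccc23)nn1`, gives 63%; and compound 3, `COc1ccc(/C=C/C(=O)/C=C/c2ccc(OCc3cn(CCCOc4cc(=O)oc5ccccc45)nn3)c(OC)c2)cc1`, gives 54%. Between compound 2 and compound 1 the change is hydrogen in place of methoxy on an aromatic carbon, and it brings a number 8 percentage points lower from compound 2 to compound 1 (within the scatter). Compound 4, `COc1cc(/C=C/C(=O)/C=C/c2ccccc2)ccc1OCc1cn(CCCOc2cc(=O)oc3ccccc23)nn1`, has not yet been measured; it differs from compound 3 by hydrogen in place of methoxy on an aromatic carbon. Going by the values given here, that is the same kind of change as the one from compound 2 to compound 1, but not the same: there the place was ortho to a methoxy group, meta to a large group and meta to a methoxy group, whereas here it is para to a large group. The difference between the cores of compound 3 and compound 2 is not broken down here. For compound 4 the step is expected to be a number 6 percentage points lower from compound 3 to compound 4 (within the scatter), because a number 8 percentage points lower from compound 2 to compound 1 (within the scatter) stayed within the scatter. Compound 4 is therefore estimated to give 48% in this assay, within 30% to 64%.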

Compound 4, percent growth inhibition at one concentration: 45%
Beside the measured number, compound 4's estimate is 3 percentage points above it, within the range that was stated.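

Replacing the methoxy group of the 4-methoxyphenyl end with hydrogen gives, in this assay, a number 9 percentage points lower from compound 3 to compound 4 (within the scatter). Set beside the earlier case, the same kind of change reads alike on the two cores: the same change on two cores in this assay, a number 8 percentage points lower (within the scatter) from compound 2 to compound 1 and a number 9 percentage points lower (within the scatter) from compound 3 to compound 4, 1 percentage points apart, within the scatter of two such steps. Going by these compounds alone, this agreement shows only that the step carried over between these two cores without a visible gap; each step lies within the scatter on its own, so it does not establish that the change lowers growth inhibition on either core, the two steps do not sit at the same place on the ring, and two cores say nothing about any other core.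

The compounds shown leave open how a hydroxy group, an amine or a carboxylic acid at that place would read in this assay. They also leave open whether the step would hold with a longer chain in the linker.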